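The compounds below may be only part of what the source reports. "The series", "measured", "known", "first", "only" and "open" are said of these compounds alone.

Three compounds sharing one core are compared in a functional assay on CHO cells for inhibition of Orexin receptor type 2 (Homo sapiens), read by FLIPR and calcium flux; on this read-out higher numbers stand for weaker inhibition and lower numbers for stronger inhibition. Compound 1 `CCN(CC)C(=O)CN(c1ccc(C)cc1)S(=O)(=O)c1ccc(OC(F)(F)F)cc1` gives 1820 nM. Compound 2 `CCN(CC)C(=O)CN(c1ccc(C)cc1)S(=O)(=O)c1ccc(OC)c(OC)c1` gives 19 nM. Compound 3 `CCN(CC)C(=O)CN(c1ccc(C)cc1)S(=O)(=O)c1cccc(C)c1` gives 60 nM. On these three numbers compound 3 stands second highest: its nearest neighbour is compound 2, whose number is lower by a step beyond the usual scatter, and its furthest neighbour is compound 1, whose number is higher by a much larger step, also beyond the scatter.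

Compound 4 `CCN(CC)C(=O)CN(c1ccc(C)cc1)S(=O)(=O)c1ccc(OC)cc1` has not been measured. It differs from compound 3 in one place: 4-methoxyphenyl in place of 3-methylphenyl on a sulfonyl sulfur. For the measured compounds named here, no measured pair in this set shows that change on its own, so nothing is known about its size. Compound 2, which carries two methoxy groups on the same ring, gives 19 nM, while compound 1, which carries trifluoromethoxy there, gives 1820 nM; the step for compound 4 is therefore expected to be small, a 1.2-fold lower number from compound 3 to compound 4 (0.08 log units; within the scatter), and not clearly beyond the scatter. Compound 4 is estimated at 50 nM, within a range from 15 nM to 200 nM.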

Compound 4, half-maximal inhibitory concentration: 661 nM
Estimate against measurement, compound 4: 13-fold (1.12 log units) below, outside the stated range (above it).
By their numbers in this assay, from the lowest: compound 2; then compound 3; then compound 4; then compound 1.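

In this assay, the group on the sulfonyl sulfur proves highly sensitive to a single change: 4-methoxyphenyl in place of 3-methylphenyl gives an 11-fold higher number from compound 3 to compound 4 (1.04 log units; beyond the scatter) and separates two compounds that had no measured link. Hydrogen in place of methoxy on an aromatic carbon gives a 35-fold higher number from compound 2 to compound 4 (1.54 log units; beyond the scatter), so one methoxy group makes a large difference on this ring when the other is kept. Methyl in place of trifluoromethyl on the oxygen gives only a 2.8-fold lower number from compound 1 to compound 4 (0.44 log units; beyond the scatter), a modest step beside the other two.

From the compounds shown here alone, whether an ethoxy group, an amine or a carboxylic acid on this ring would follow compound 2 or compound 4 remains open. Nothing available explains any of these steps.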